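Adding a Second Chloro to the Benzylic Aryl Ring

This account rests on a few compounds, and the source may have more. Where it says the series, first, only, none or still open, it means among the compounds named here.

Compound 2 `Cc1cc(S(N)(=O)=O)ccc1NC(=O)COc1ccc(Cl)cc1C(O)c1cccc(Cl)c1` is measured in an ADME assay on C8166 cells (Homo sapiens) for cytotoxicity, read by MTT assay (on this read-out lower numbers stand for higher toxicity in this test and higher numbers for lower toxicity in this test), where compound 2 gives 33300 nM. Compound 1 `Cc1cc(S(N)(=O)=O)ccc1NC(=O)COc1ccc(Cl)cc1C(O)c1ccccc1` gives 33400 nM, which matches compound 2 within the scatter, while compound 3 `Cc1cc(S(N)(=O)=O)ccc1NC(=O)COc1ccc(Cl)cc1C(O)c1cccc(C)c1C` gives 218000 nM, and the step is a 6.5-fold higher number from compound 2 to compound 3 (0.82 log units; beyond the scatter). Compound 4 `Cc1cc(S(N)(=O)=O)ccc1NC(=O)COc1ccc(Cl)cc1C(O)c1cc(Cl)cc(Cl)c1` differs from compound 2 by one change: chloro in place of hydrogen on an aromatic carbon. The step that bears on it most is the same kind of change from compound 1 to compound 2, which gave a 1.0-fold lower number from compound 1 to compound 2 (0.00 log units; within the scatter). The larger steps of a 6.5-fold higher number from compound 1 to compound 3 (0.81 log units; beyond the scatter) and a 6.5-fold higher number from compound 2 to compound 3 (0.82 log units; beyond the scatter) involve a different group. A step of no more than the scatter is therefore expected, namely a 1.0-fold lower number from compound 2 to compound 4 (0.00 log units; within the scatter). Compound 4 is estimated at 33000 nM, within the range 15000 nM to 75000 nM.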

Compound 4, half-maximal cytotoxic concentration: 13100 nM
For compound 4 the middle estimate is 2.5-fold (0.40 log units) above the measured one; measured number below the stated range.
By their numbers in this assay, from the lowest: compound 4; then compounds 2 and 1 (each within the scatter of the next); then compound 3.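

In this assay a chloro in place of hydrogen on this ring can matter after all: the second chloro brings a 2.5-fold lower number from compound 2 to compound 4 (0.41 log units; beyond the scatter) and sets the 3,5-dichlorophenyl compound apart from the plain phenyl too, with a 2.5-fold lower number from compound 1 to compound 4 (0.41 log units; beyond the scatter) over both changes. The choice of ring groups now also spans a wider range, with a 17-fold lower number from compound 3 to compound 4 (1.22 log units; beyond the scatter) on swapping one pattern for the other.

On these data alone, whether an amine or a methoxy group in this same place would move the number as chloro does stays open. No measurement shown explains this shift.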